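The source may report more compounds than this note shows. Statements on the series, on what has been measured and on what is new or still open speak of the compounds shown alone.

Within the data shown here, in an ADME assay, at pH 5 (a higher number here means that the compound lasts longer, a lower number that the compound disappears faster), only two compounds have been measured so far. Compound 1 (`COc1ccnc(C[S+]([O-])c2nc3cc(OC(F)F)ccc3[nH]2)c1C`) gives 0.17 h, and compound 2 (`COc1ccnc(C[S+]([O-])c2nc3cc(OC(F)(F)C(F)F)ccc3[nH]2)c1`) gives 0.8 h, the higher of the two numbers and beyond the usual scatter from compound 1. Compound 3 (`COc1ccnc(C[S+]([O-])c2nc3cc(OC(F)(F)C(F)F)ccc3[nH]2)c1C`) keeps the structure of compound 2 apart from one change: methyl in place of hydrogen on an aromatic carbon, turning 4-methoxypyridin-2-yl into 4-methoxy-3-methylpyridin-2-yl. Among the measured compounds shown here, no measured pair isolates this change. For the measured compounds named here, the only hint comes from compound 1, which already holds the 4-methoxy-3-methylpyridin-2-yl group but also differs elsewhere, and which stands low at 0.17 h. A modest fall in this assay, near the edge of the scatter, is therefore expected, estimated as a 2.3-fold lower number from compound 2 to compound 3 (0.36 log units; beyond the scatter). The half-life expected for compound 3 is 0.35 h, with an estimated range of 0.17 h to 0.75 h.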

Compound 3, half-life: 0.3 h
For compound 3 the middle estimate is 1.2-fold (0.07 log units) above the measured one; low and high end bracket the measured number.
By their numbers in this assay, from the lowest: compounds 1 and 3 (each within the scatter of the next); then compound 2.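

In this assay, among these compounds, turning 4-methoxypyridin-2-yl into 4-methoxy-3-methylpyridin-2-yl gives a 2.7-fold lower number from compound 2 to compound 3 (0.43 log units; beyond the scatter) as the first direct reading of this change, a modest step on one pair of compounds. With the 4-methoxy-3-methylpyridin-2-yl group held fixed, difluoromethyl in place of hydrogen on the saturated chain carbon gives a 1.8-fold higher number from compound 1 to compound 3 (0.25 log units; within the scatter) and so does not separate the two side chains in this assay. Nothing shown here bears on the reason for either step. The compounds shown carry only hydrogen or methyl at this place, so what an ethyl, a chlorine or an amine would do there stays open. Also open, going by these compounds, is whether the methyl step would be of similar size with the side chain of compound 1 in place.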